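Methoxy for methyl on the aryl amide of compound 2

This account rests on a few compounds, and the source may have more. Where it says the series, first, only, none or still open, it means among the compounds named here.

Compound 2 `Cc1ccc(C(=O)N2CC(=O)N(C3CCCCC3)C(=O)C23CCN(Cc2ccccc2)CC3)cc1` carries a (4-methylphenyl)carbonyl group on a shared core. Within the data shown here, in an assay on membranes from brain (strain Dunkin Hartley) for displacement of a labelled ligand from Sigma non-opioid intracellular receptor 1 (Cavia porcellus), read by scintillation counting, with a stated time of 120 min (on this read-out higher numbers stand for weaker inhibition and lower numbers for stronger inhibition), compound 2 gives 11.1 nM, the highest of the two numbers measured so far. Among the measured compounds shown here, its nearest neighbour is compound 1 `O=C1CN(C(=O)c2ccccc2)C2(CCN(Cc3ccccc3)CC2)C(=O)N1C1CCCCC1`, which has a hydrogen where compound 2 has the methyl; in this assay compound 1 gives 7.2 nM, and the single measured step of a 1.5-fold higher number from compound 1 to compound 2 (0.19 log units; within the scatter) lies within the scatter, so the two values cannot be told apart.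

Compound 3 `COc1ccc(C(=O)N2CC(=O)N(C3CCCCC3)C(=O)C23CCN(Cc2ccccc2)CC3)cc1` is the next variation. The change is methoxy in place of methyl on an aromatic carbon. For the measured compounds named here, the only measured step that bears on this change is a 1.5-fold higher number from compound 1 to compound 2 (0.19 log units; within the scatter): placing a methyl on that aromatic carbon changed little. A methoxy is a different group, yet this aromatic carbon has so far taken a change without a step beyond the scatter, so for compound 3 in this assay no more than the usual scatter is expected. The expected step of a 1.1-fold higher number from compound 2 to compound 3 (0.03 log units; within the scatter) is therefore small. For compound 3 the estimate is 12 nM, with a range from 5 nM to 30 nM.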

Compound 3, inhibition constant: 5.9 nM
For compound 3 the middle estimate is 2.0-fold (0.31 log units) above the measured one; the measured number falls inside the stated range.
By their numbers in this assay, from the lowest: compounds 3, 1 and 2 (each within the scatter of the next).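

In this assay, methoxy in place of methyl gives a 1.9-fold lower number from compound 2 to compound 3 (0.27 log units; within the scatter), and methoxy in place of hydrogen gives a 1.2-fold lower number from compound 1 to compound 3 (0.09 log units; within the scatter). The earlier pair showed only that a single added carbon made no difference beyond the scatter; this aromatic carbon has now also taken a group that brings an oxygen and a hydrogen-bond acceptor, again with no step beyond the scatter, so hydrogen, methyl and methoxy cannot be told apart here. Nothing available explains why these three compounds sit so close together.

All three groups at this position are uncharged and hold at most two heavy atoms, so an amine, a carboxylic acid or a longer chain such as butoxy on the same carbon could still give a step beyond the scatter. From the compounds shown here alone, whether methoxy would behave the same on another carbon of this ring, or alongside a change elsewhere on the shared core, also remains open.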